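A few compounds are considered here, and "the series" means these few. Any claim that something is new, unique, unknown or untested is made for them only; others in the source may bear on it.

Measured in a functional assay on V79 cells (Cricetulus griseus) for cytotoxicity, read by colony formation; a lower number here means a stronger inhibitor, a higher number a weaker inhibitor:
- Compound 1 `Nc1c(F)c(N2CCC(N)C2)cc2c1c(=O)c(C(=O)O)cn2C1CC1`: 54 ug/mL
- Compound 2 `Nc1c(F)c(N2CCC(N)C2)c(Cl)c2c1c(=O)c(C(=O)O)cn2C1CC1`: 59 ug/mL

In this assay, compound 2 gives 59 ug/mL, which lies within the scatter of the value for compound 1, so neither counts as the stronger inhibitor. The next compound, compound 3 `COc1c(N2CCC(N)C2)c(F)c(N)c2c(=O)c(C(=O)O)cn(C3CC3)c12`, has methoxy in place of chloro on an aromatic carbon, ortho to a 3-aminopyrrolidin-1-yl group: methoxy in place of chloro on an aromatic carbon. Going by the values given here, one measured step bears on this same carbon: a 1.1-fold higher number from compound 1 to compound 2 (0.04 log units; within the scatter), where chloro replaces hydrogen. That step is within the scatter, so swapping the group at this carbon has not yet moved the number measurably. However, no compound with methoxy has been measured, and a single step is thin evidence, so the range must stay wide. No change beyond the scatter is expected, and the estimated step is a 1.0-fold higher number from compound 2 to compound 3 (0.01 log units; within the scatter). For compound 3, the expected value is 60 ug/mL, with an estimated range of 28 ug/mL to 125 ug/mL.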

Compound 3, half-maximal inhibitory concentration: 100 ug/mL
The estimate for compound 3 lay 1.7-fold (0.22 log units) below the measured number, within the range that was stated.
By their numbers in this assay, from the lowest: compounds 1, 2 and 3 (each within the scatter of the next).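

In this assay, methoxy on this aromatic carbon gives a 1.7-fold higher number from compound 2 to compound 3 (0.23 log units; within the scatter) and a 1.9-fold higher number from compound 1 to compound 3 (0.27 log units; within the scatter), so hydrogen, chloro and methoxy at this position now all fall within the scatter of one another. Methoxy is the first group here that brings in a hydrogen-bond acceptor, and even with that addition, the number has not moved measurably in these three compounds. No measurement available here explains these numbers.

On these data alone, it remains open whether an amine, a nitrile or a longer chain such as butoxy on this carbon would move the number beyond the scatter. It is also unknown whether this tolerance would hold if a piperazine ring replaced the 3-aminopyrrolidin-1-yl group.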